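The source may report more compounds than this note shows. Statements on the series, on what has been measured and on what is new or still open speak of the compounds shown alone.

Measured compounds:
compound 1, `COc1ccc(CSc2nc(Cc3ccc(Br)cc3)c(C)c(=O)[nH]2)cc1`: > 290000 nM
compound 2, `CCc1c(Cc2ccc(Br)cc2)nc(SCc2ccc(OC)cc2)[nH]c1=O`: > 281000 nM
compound 3, `CCc1c(Cc2cccc3ccccc23)nc(SCc2ccc(OC)cc2)[nH]c1=O`: 261000 nM

All three were tested in an ADME assay on MT4 cells (Homo sapiens) for cytotoxicity, read by MTT assay; a higher number here means that more compound is tolerated, a lower number that less compound is tolerated. For compound 1 the value > 290000 nM is a limit of the assay, not a number. For compound 2 the value > 281000 nM is likewise a limit. Only compound 3 gives a number, 261000 nM. The change methyl in place of hydrogen on a saturated chain carbon bound to an aromatic carbon therefore gives a step that the two limits leave unreadable from compound 1 to compound 2 because the limit of > 281000 nM in this assay, at which 1 of the 3 values shown sits, and the limit of > 290000 nM in this assay, at which 1 of the 3 values shown sits, are both limits. The change from compound 2 to compound 3 gives an at least 1.0-fold lower number from compound 2 to compound 3 (0.03 log units; that floor lies within the scatter). The difference between the cores of compound 1 and compound 3 is not broken down here.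

Compound 4, `COc1ccc(CSc2nc(Cc3cccc4ccccc34)c(C(C)C)c(=O)[nH]2)cc1`, is not yet measured in this assay. It differs from compound 3 by methyl in place of hydrogen on a saturated chain carbon bound to an aromatic carbon and a saturated chain carbon, the same kind of change as from compound 1 to compound 2, but here the place is on a saturated chain carbon bound to an aromatic carbon and a saturated chain carbon, whereas before it was on a saturated chain carbon bound to an aromatic carbon. With nothing readable from the earlier step, the expected step is a 1.1-fold lower number from compound 3 to compound 4 (0.05 log units; within the scatter), a small one. Compound 4 is thus estimated at 230000 nM, between 110000 nM and 300000 nM.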

Compound 4, half-maximal cytotoxic concentration: 37400 nM
The estimate for compound 4 lay 6.1-fold (0.79 log units) above the measured number; the whole stated range lies above it.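

In this assay, the change from ethyl to isopropyl gives a 7.0-fold lower number from compound 3 to compound 4 (0.84 log units; beyond the scatter), a clear drop in the amount of compound tolerated, but this is a single readable step on a single core. Going by these compounds, whether the same kind of change, methyl in place of hydrogen, does the same on the core of compound 1 stays unknown, because compound 2 gives a limit and not a number: the limit of > 281000 nM in this assay, at which 1 of the 4 values shown sits. Compound 1 likewise gives a limit and not a number: the limit of > 290000 nM in this assay, at which 1 of the 4 values shown sits.

On these data alone, it remains open whether the drop depends on isopropyl itself or would also appear with a longer chain such as propyl or butyl. Also open, as far as these compounds go, is how isopropyl would behave with 4-bromophenyl in place of the naphthalen-1-yl group.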